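Methyl to ethyl on the aryl ether of compound 3

A few compounds are considered here, and "the series" means these few. Any claim that something is new, unique, unknown or untested is made for them only; others in the source may bear on it.

Compound 1 `CCOc1c(-c2occ(C)c2C(=O)O)ccc2c(CC)cccc12` in a functional assay on ZR-75-1 cells (Homo sapiens) for cytotoxicity, read by MTT assay, with a stated time of 72 h (a higher number here means that more compound is needed for the effect, a lower number that less compound is needed), reports only the limit > 10 ug/mL. Compound 2 `CCOc1c(-c2occ(C)c2C(=O)OC)ccc2c(CC)cccc12` gives 1.2 ug/mL. Compound 3 `CCc1cccc2c(OC)c(-c3occ(C)c3CO)ccc12` again reaches only the limit > 10 ug/mL.

Compound 3 therefore stands at the ceiling of the assay, with no number of its own; it shares this position with compound 1, as the limit of > 10 ug/mL in this assay, at which 2 of the 3 values shown sit, records, and only compound 2 reports a number below that ceiling. The step to compound 4 `CCOc1c(-c2occ(C)c2CO)ccc2c(CC)cccc12` is methyl in place of hydrogen on a saturated chain carbon bound to an oxygen on an aromatic ring, or methoxy to ethoxy. Among the measured compounds shown here, the single measured step, an at least 8.3-fold lower number from compound 1 to compound 2 (0.92 log units; beyond the scatter), concerns the carboxylic acid against its methyl ester and does not touch the ether, so no measured step bears directly on the present change. Compounds 1 and 2 both already carry the ethoxy group, and compound 1 sits at the limit with it, so the ethoxy group on its own gives no number here.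

For compound 4 the expectation is therefore a value close to where compound 3 stands, with a step that the limit leaves unreadable from compound 3 to compound 4 not beyond the scatter. Compound 4 is estimated at 15 ug/mL, within 5 ug/mL to 45 ug/mL, most likely reported again only as a limit.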

Compound 4, concentration for half-maximal effect: 1.4 ug/mL
Compound 4: the middle estimate sits 11-fold (1.03 log units) above what was measured; measured number below the stated range.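

Working notes: in this assay, methoxy to ethoxy with hydroxymethyl held in place gives an at least 7.1-fold lower number from compound 3 to compound 4 (0.85 log units; beyond the scatter), so methyl in place of hydrogen on a saturated chain carbon bound to an oxygen on an aromatic ring is a change the read-out responds to, the only such step shown at this position. With the ethoxy group held, the hydroxymethyl and methoxycarbonyl compounds read alike, a 1.2-fold higher number from compound 2 to compound 4 (0.07 log units; within the scatter), while the carboxy compound stands apart, an at least 7.1-fold lower number from compound 1 to compound 4 (0.85 log units; beyond the scatter), so of these three groups on the aromatic carbon only carboxy leaves the series at the limit. The steps starting from compound 1 and compound 3 give only a lower bound on their size, because each starts from a limit and not from a number: the limit of > 10 ug/mL in this assay, at which 2 of the 4 values shown sit.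

From the compounds shown here alone, whether the ether change carries the same weight with methoxycarbonyl as the partner group stays open, as does how a longer chain such as propoxy would read at the ether. An amine such as aminomethyl in place of hydroxymethyl also remains unplaced, and all readings here come from this assay alone.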